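A few compounds are considered here, and "the series" means these few. Any claim that something is new, unique, unknown or untested is made for them only; others in the source may bear on it.

Three compounds have been measured in a functional assay on HT-29 cells (Homo sapiens) for antiproliferative activity, read by sulforhodamine B assay, with a stated time of 72 h; on this read-out higher numbers stand for weaker inhibition and lower numbers for stronger inhibition:

Compound 1 `CC(C)c1cccc(C(C)C)c1NC(=S)N/N=C/c1ccc2ccccc2n1`: 20700 nM
Compound 2 `Fc1ccccc1NC(=S)N/N=C/c1ccc2ccccc2n1`: > 100000 nM
Compound 3 `CN(C)C(=S)N/N=C/c1ccc2ccccc2n1`: 20 nM

Compound 2 stands at a limit of this assay rather than at a number; it sits at the limit of > 100000 nM in this assay, at which 1 of the 3 values shown sits. Within the data shown here, no change between two measured compounds has been followed, so no measured step guides the next one. Compound 4 `COc1ccccc1NC(=S)N/N=C/c1ccc2ccccc2n1` differs from compound 2 in one place: methoxy in place of fluoro on an aromatic carbon. Compound 1 gives 20700 nM, while compound 3 gives 20 nM in this assay. The step from compound 2 to compound 4 is expected to be an at least 1.6-fold lower number from compound 2 to compound 4 (0.22 log units; that floor lies within the scatter), toward somewhat stronger inhibition, with a fair chance that compound 4 also yields only a limit. Compound 4 is estimated at 60000 nM, with a range from 10000 nM to 150000 nM.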

Compound 4, half-maximal inhibitory concentration: > 100000 nM
Compound 4: no number, only a limit (the forecaster's own chance of this, stated with the estimate: 45%); middle value at least 1.6-fold (0.22 log units) away from the limit.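

In this assay compound 4 gives > 100000 nM, a limit and not a number. Among these compounds, compound 2 gives > 100000 nM, also a limit, and no step between compound 2 and compound 4 can be read. The compounds shown leave open how the 2-fluorophenyl and 2-methoxyphenyl groups compare.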